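The source may hold more compounds than are shown below. What is called first, only, known or untested is meant among the compounds shown, and "the series" means these compounds.

In an ADME assay on HepG2 cells (Homo sapiens) for cytotoxicity, read by CellTiter-Glo, with a stated time of 72 h (on this read-out lower numbers stand for an effect already at smaller amounts and higher numbers for an effect only at larger amounts of compound), compound 1 `C/C1=C/C2=C[C@H](C)C[C@@]23O[C@]2(CC(C)(C)C[C@@H]2[C@@]1(O)C#N)[C@@H](C)C3=O` gives 26000 nM, compound 2 `CC1=C2CC(C)(C)/C=C/[C@H](O)/C(C)=C\C3=C[C@H](C)C[C@]3(O2)C1=O` gives 18700 nM and compound 3 `COc1ccc(/C2=C\C(=O)/C(C)=C\C3=C[C@H](C)C[C@@]34OC(=C(C)C4=O)CC2(C)C)cc1` gives 26000 nM. Compound 3 thus stands level with compound 1, and its gap to compound 2 lies within the usual scatter. No two of these measured compounds differ in just one place, so the data show no single change on its own. Compound 4 `CC1=C2CC(C)(C)/C(c3ccc(C(F)(F)F)cc3)=C/C(=O)/C(C)=C\C3=C[C@H](C)C[C@]3(O2)C1=O` has trifluoromethyl in place of methoxy on an aromatic carbon, para to a large group (trifluoromethyl in place of methoxy on an aromatic carbon). With only these three close values as a guide, no step beyond the scatter is expected in this assay. The estimated step, a 1.2-fold lower number from compound 3 to compound 4 (0.07 log units; within the scatter), stays within that scatter. The expected value for compound 4 is 22000 nM, with an estimated range from 11000 nM to 42000 nM.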

Compound 4, half-maximal effective concentration: 26000 nM
Compound 4: the middle estimate sits 1.2-fold (0.07 log units) below what was measured, and the stated range covers the measured number.
By their numbers in this assay, from the lowest: compounds 2, 1, 3 and 4 (each within the scatter of the next).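

In this assay, within the data shown here, the one pair here that differs in a single place gives no change at the digits printed from compound 3 to compound 4 (within the scatter) when trifluoromethyl replaces methoxy on an aromatic carbon, para to a large group. At this position the read-out therefore stays flat through this change, even though the group gains heavy atoms and loses its hydrogen-bond acceptor. No measurement here gives a reason for this. As far as these compounds go, whether an amine or a carboxylic acid in the same place would leave the number equally unmoved remains open, as does whether this exchange would behave alike elsewhere on the molecule.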